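The compounds below may be only part of what the source reports. "The series", "measured", "known", "first", "only" and "open" are said of these compounds alone.

Compound 1 `COc1cc(-c2nnc3n2NC(c2ccco2)C(C(=O)c2ccc(Br)cc2)S3)cc(OC)c1OC` is the starting point. In a functional assay on A549 cells (Homo sapiens) for cytotoxicity, read by MTT assay, with a stated time of 48 h (on this read-out lower numbers stand for stronger inhibition and higher numbers for weaker inhibition), compound 1 gives 42100 nM, the lowest of the three numbers in hand. Compound 2 `COc1cc(-c2nnc3n2NC(c2ccco2)C(C(=O)c2ccc(Cl)cc2)S3)cc(OC)c1OC` gives 51400 nM in this assay, and compound 3 `COc1cc(-c2nnc3n2NC(c2ccco2)C(C(=O)c2ccc(O)cc2)S3)cc(OC)c1OC` gives 93400 nM. The step of a 1.2-fold higher number from compound 1 to compound 2 (0.09 log units; within the scatter) stays within the scatter, a 1.8-fold higher number from compound 2 to compound 3 (0.26 log units; within the scatter) likewise, while a 2.2-fold higher number from compound 1 to compound 3 (0.35 log units; beyond the scatter) reaches modestly beyond it. Compound 4 `COc1cc(-c2nnc3n2NC(c2ccco2)C(C(=O)c2cccc(Br)c2)S3)cc(OC)c1OC` differs from compound 1 in a single place: 3-bromophenyl in place of 4-bromophenyl on a carbonyl carbon. Going by the values given here, none of the measured steps bears directly on this change: each of them swaps the group standing on the ring without moving it, and even the largest of them is modest. Among the compounds with values here, with no precedent for the shift itself, and with every measured step small, the step from compound 1 to compound 4 is not expected to go beyond the scatter in this assay, in either direction. Compound 4 is therefore expected to give about 45000 nM in this assay, with a range from 20000 nM to 100000 nM. For compound 4 this estimate means an expected step of a 1.1-fold higher number from compound 1 to compound 4 (0.03 log units; within the scatter), which is expected to remain within the scatter.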

Compound 4, half-maximal inhibitory concentration: 36900 nM
The estimate for compound 4 lay 1.2-fold (0.09 log units) above the measured number; low and high end bracket the measured number.
By their numbers in this assay, from the lowest: compounds 4, 1, 2 and 3 (each within the scatter of the next, the first and the last beyond it).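

Going by these compounds alone, with 3-bromophenyl in place of 4-bromophenyl on the carbonyl carbon, a 1.1-fold lower number from compound 1 to compound 4 (0.06 log units; within the scatter) in this assay, so this assay does not separate the two bromophenyl compounds, and this is the first shift of the group on the ring rather than a swap of it. Likewise, a 1.4-fold lower number from compound 2 to compound 4 (0.14 log units; within the scatter), while a 2.5-fold lower number from compound 3 to compound 4 (0.40 log units; beyond the scatter) reaches modestly beyond the scatter, so compound 3 stands apart from both bromophenyl compounds but not from compound 2. Nothing measured here offers a reason for these steps.

From the compounds shown here alone, whether a chloro or hydroxy group would tolerate the same shift remains open, as does the effect of an amine or a carboxylic acid on this ring. The compounds shown also leave open whether any change at this place can move the number by more than a modest step.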